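This account rests on a few compounds, and the source may have more. Where it says the series, first, only, none or still open, it means among the compounds named here.

The study turns on an ADME assay on Vero cells (Chlorocebus sabaeus) for cytotoxicity, read by WST assay (a lower number here means that less compound is tolerated, a higher number that more compound is tolerated), and on how little it distinguishes the compounds at hand. Compound 1 `O=c1[nH]c(Nc2cc(F)cc(F)c2)nc2cc(Cl)ccc12` is the starting point. In this assay compound 1 gives >= 18000 nM, which is a limit of the assay rather than a number. Compound 3 `O=c1[nH]c(Nc2cc(F)cc(F)c2)nc2c(Cl)c(Cl)ccc12` differs from compound 1 by chloro in place of hydrogen on an aromatic carbon. In this assay compound 3 gives > 25000 nM, again a limit. The step that the two limits leave unreadable from compound 1 to compound 3 cannot therefore be sized. Compound 2 `O=c1[nH]c(Nc2cc(Cl)cc(Cl)c2)nc2cc(Cl)ccc12` has a different core; the difference between the two cores is not broken down here. In this assay compound 2 gives > 25000 nM, also a limit. Compound 4 `O=c1[nH]c(Nc2cc(Cl)cc(Cl)c2)nc2c(Cl)c(Cl)ccc12` has not yet been measured and differs from compound 2 by chloro in place of hydrogen on an aromatic carbon, the same change that leads from compound 1 to compound 3. Two facts frame the expectation: the limit of > 25000 nM in this assay, at which 2 of the 3 values shown sit, and (the limit of >= 18000 nM in this assay, at which 1 of the 3 values shown sits). On that basis the step that the limit leaves unreadable from compound 2 to compound 4 is expected to be small, and compound 4 is estimated at 30000 nM, between 15000 nM and 60000 nM, most likely reported as a limit.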

Compound 4, half-maximal cytotoxic concentration: > 25000 nM
Compound 4: only a limit was reported; the forecaster's own chance of this, stated with the estimate: 85%; the middle value lies beyond the limit too.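

In this assay compound 4 gives > 25000 nM, which is a limit of the assay and not a number. For the compounds shown here, compound 2 also stands at a limit, so no step between compound 2 and compound 4 can be read. The compounds shown leave open how large any of the four half-maximal cytotoxic concentrations is, and whether chloro in place of hydrogen on an aromatic carbon shifts it at all.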